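Working notes: from compound 3 to compound 4

A few compounds are considered here, and "the series" means these few. Any claim that something is new, unique, unknown or untested is made for them only; others in the source may bear on it.

Measured so far in a functional assay with Homo sapiens as the target; on this read-out lower numbers stand for stronger inhibition and higher numbers for weaker inhibition
Compound 1 `CC(C)[C@H](NC(=O)COc1cccc2ccccc12)C(=O)N[C@@H](CC(=O)O)C(=O)COc1ccc(C(F)(F)F)cc1` gives 12300 nM
Compound 2 `CC(C)[C@H](NC(=O)COc1cccc2ccccc12)C(=O)N[C@@H](CC(=O)O)C(=O)COc1ccc([N+](=O)[O-])cc1` gives 22800 nM
Compound 3 `CC(C)[C@H](NC(=O)COc1cccc2ccccc12)C(=O)N[C@@H](CC(=O)O)C(=O)COc1cccc(F)c1` gives 12000 nM

Compound 3 stands level with the other two, as a 1.0-fold lower number from compound 1 to compound 3 (0.01 log units; within the scatter) and a 1.9-fold lower number from compound 2 to compound 3 (0.28 log units; within the scatter) leave no order among them. Compound 4 `CC(C)[C@H](NC(=O)COc1cccc2ccccc12)C(=O)N[C@@H](CC(=O)O)C(=O)COc1cc(F)cc(F)c1F` brings 2,3,5-trifluorophenyl in place of 3-fluorophenyl on an oxygen on a saturated carbon. Those two steps and a 1.9-fold higher number from compound 1 to compound 2 (0.27 log units; within the scatter) bear on it, as each swaps the same aryl group, and none goes beyond the scatter. None of them involves the entering group, so this is only a rough guide. No step beyond the scatter is therefore expected in this assay in either direction. An estimated 1.2-fold lower number from compound 3 to compound 4 (0.08 log units; within the scatter) is what this amounts to. Compound 4 is expected at 10000 nM (estimated range 3000 nM to 26000 nM).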

Compound 4, half-maximal inhibitory concentration: 11200 nM
The estimate for compound 4 lay 1.1-fold (0.05 log units) below the measured number, within the range that was stated.
By their numbers in this assay, from the lowest: compounds 4, 3, 1 and 2 (each within the scatter of the next, the first and the last beyond it).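

In this assay, 2,3,5-trifluorophenyl on this oxygen stays level with the other aryl groups, with a 1.1-fold lower number from compound 3 to compound 4 (0.03 log units; within the scatter) and a 1.1-fold lower number from compound 1 to compound 4 (0.04 log units; within the scatter). For the compounds shown here, the modest 2.0-fold lower number from compound 2 to compound 4 (0.31 log units; beyond the scatter) is the first step at this position to pass the scatter, although compound 2 and compound 3 remain within the scatter of each other. No available evidence bears on this result.

Open, going by these compounds, is whether an amine or a longer chain in place of the aryl group would move the number in this assay beyond the scatter from compound 4.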